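From an ethoxyethyl chain to a chlorobenzyl group

A few compounds are considered here, and "the series" means these few. Any claim that something is new, unique, unknown or untested is made for them only; others in the source may bear on it.

Measured in an ADME assay on RAW264.7 cells (Mus musculus) for cytotoxicity, read by MTT assay, with a stated time of 24 h, in the absence of a further agent; a higher number here means a weaker inhibitor, a lower number a stronger inhibitor:
compound 1 `COc1cc(OC)c2c(c1)C(C(O)c1ccc(O)cc1)OC2=O`: > 40000 nM
compound 2 `COCCOc1ccc(C(O)C2OC(=O)c3c(OC)cc(OC)cc32)cc1`: > 40000 nM
compound 3 `CCOCCOc1ccc(C(O)C2OC(=O)c3c(OC)cc(OC)cc32)cc1`: > 40000 nM

Compound 3 gives > 40000 nM, which is a limit and not a number. Compound 1 and compound 2 also stand only at limits. Compound 4 `COc1cc(OC)c2c(c1)C(C(O)c1ccc(OCc3ccc(Cl)cc3)cc1)OC2=O` changes one group of compound 3: 4-chlorophenyl in place of ethoxymethyl on a saturated chain carbon bound to an oxygen on an aromatic ring. Read one bond further out, 2-ethoxyethyl gives way to 4-chlorobenzyl. The measured steps nearest to this are a step that the two limits leave unreadable from compound 1 to compound 3, a step that the two limits leave unreadable from compound 1 to compound 2 and a step that the two limits leave unreadable from compound 2 to compound 3. None of them has a size to carry over, and the entering group holds a ring that the leaving group lacks. The evidence is the limit of > 40000 nM in this assay, at which 3 of the 3 values shown sit. The expected change in this assay is a number no higher from compound 3 to compound 4 (the limit leaves the size open), with no shift in either direction beyond the scatter. Compound 4 is estimated at 40000 nM, with an expected range from 12000 nM to 80000 nM.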

Compound 4, half-maximal inhibitory concentration: > 40000 nM
Compound 4: only a limit was reported; the forecaster's own chance of this, stated with the estimate: 70%; the middle value sits exactly at the limit.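

Within the data shown here, compound 1, compound 2, compound 3 and compound 4 all stand only at limits, and no step between them can be read. The compounds shown leave open how their groups on the oxygen rank in this assay.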